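Amine in Place of Acid on a Nucleoside Ester Chain

The source may report more compounds than this note shows. Statements on the series, on what has been measured and on what is new or still open speak of the compounds shown alone.

Compound 1, `Cc1cn(C2CC(N=[N+]=[N-])C(COC(=O)OCCCC(=O)OC(C)(C)C)O2)c(=O)[nH]c1=O`, and compound 2, `Cc1cn(C2CC(N=[N+]=[N-])C(COC(=O)CCCC(=O)O)O2)c(=O)[nH]c1=O`, share the same core and differ only at the far end of the ester chain. In a functional assay on MT4 cells (Homo sapiens) for cytotoxicity (on this read-out lower numbers stand for higher toxicity in this test and higher numbers for lower toxicity in this test), compound 1 reaches only the limit of > 50000 nM, not a measured number. In this assay compound 2 likewise sits at the limit of > 50000 nM. Both values shown thus stand at the limit of > 50000 nM in this assay, at which 2 of the 2 values shown sit, so compound 2 stands level with the one other compound shown, and no measured step is available to lean on. Compound 3, `Cc1cn(C2CC(N=[N+]=[N-])C(COC(=O)CCCN)O2)c(=O)[nH]c1=O`, is not yet measured. It differs from compound 2 by amino in place of carboxy on a saturated chain carbon, three bonds along the chain from a carbonyl carbon. With only two limits in hand, the step expected from compound 2 to compound 3 in this assay is a step that the limit leaves unreadable from compound 2 to compound 3, which is taken as none beyond the scatter. Compound 3 is therefore expected to give about 60000 nM in this assay, with a range from 20000 nM to 200000 nM, and most likely to be reported again as a limit.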

Compound 3, half-maximal cytotoxic concentration: > 50000 nM
Compound 3 gave a limit, no number; the forecaster's own chance of this, stated with the estimate: 70%; the middle value does not contradict the limit.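

Within the data shown here, compound 3 also returns only a limit, not a number, so no step from compound 2 to compound 3 can be read in this assay: the limit of > 50000 nM in this assay, at which 3 of the 3 values shown sit. The compounds shown leave open how far each lies past that limit, and whether amino in place of carboxy changes the read-out at all.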